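The source may report more compounds than this note shows. Statements on the series, on what has been measured and on what is new or still open speak of the compounds shown alone.

Measured compounds:
- compound 1, `COc1ccc(OC)c(/C=C/C(=O)Nc2cc3c(Nc4ccc(F)c(Cl)c4)ncnc3cc2O[C@H]2CCOC2)c1`: 36300 nM
- compound 2, `COc1cc(/C=C/C(=O)Nc2cc3c(Nc4ccc(F)c(Cl)c4)ncnc3cc2O[C@H]2CCOC2)cc(OC)c1O`: 30500 nM
- compound 3, `COc1cc(/C=C/C(=O)Nc2cc3c(Nc4ccc(F)c(Cl)c4)ncnc3cc2OC)cc(OC)c1`: 38500 nM

In a functional assay on MCF7 cells (Homo sapiens) for cytotoxicity, read by MTT assay, with a stated time of 72 h (a higher number here means a weaker inhibitor, a lower number a stronger inhibitor), compound 1 stands second highest of the three numbers. Its nearest neighbour is compound 3, and its furthest is compound 2; both gaps are within the scatter, so the three measured values are indistinguishable. For the measured compounds named here, the one measured step at the relevant place, a 1.2-fold lower number from compound 1 to compound 2 (0.08 log units; within the scatter), lies within the scatter.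

Compound 4, `COc1cc(/C=C/C(=O)Nc2cc3c(Nc4ccc(F)c(Cl)c4)ncnc3cc2O[C@H]2CCOC2)cc(OC)c1`, has not been measured. Relative to compound 1 the change is 3,5-dimethoxyphenyl in place of 2,5-dimethoxyphenyl on a double-bonded chain carbon bound to a double-bonded chain carbon. Going by the values given here, only the step from compound 1 to compound 2 bears directly on this place, and it was within the scatter. Among the compounds with values here, compound 3 carries the same 3,5-dimethoxyphenyl group that enters in compound 4 but differs from compound 4 in another place; no step between compound 3 and compound 4 is available, and in this assay compound 3 gives a value close to compound 1.

For compound 4 the expected step is therefore a 1.0-fold higher number from compound 1 to compound 4 (0.01 log units; within the scatter), none beyond the scatter. The estimate for compound 4 is 37000 nM, with a range of 20000 nM to 70000 nM.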

Compound 4, half-maximal inhibitory concentration: 30300 nM
Estimate against measurement, compound 4: 1.2-fold (0.09 log units) above, and the stated range covers the measured number.
By their numbers in this assay, from the lowest: compounds 4, 2, 1 and 3 (each within the scatter of the next).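

In this assay, 3,5-dimethoxyphenyl in place of 2,5-dimethoxyphenyl on a double-bonded chain carbon gives a 1.2-fold lower number from compound 1 to compound 4 (0.08 log units; within the scatter), so the direct measurement of this change does not separate the two compounds. Oxolan-3-yl in place of methyl on an oxygen on an aromatic ring gives a 1.3-fold lower number from compound 3 to compound 4 (0.10 log units; within the scatter), and hydrogen in place of hydroxy on an aromatic carbon gives a 1.0-fold lower number from compound 2 to compound 4 (0.00 log units; within the scatter), so neither of these changes separates its pair either. No supporting measurement bears on this result.

Going by these compounds, whether an amine or a carboxylic acid in place of the methoxy groups on the phenyl ring would move the number beyond the scatter stays open. So does the effect of a longer chain in place of oxolan-3-yl on that oxygen.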